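A few compounds are considered here, and "the series" means these few. Any claim that something is new, unique, unknown or untested is made for them only; others in the source may bear on it.

Measured compounds in a functional assay on HCT-116 cells (Homo sapiens) for cytotoxicity, read by MTT assay, with a stated time of 72 h; on this read-out higher numbers stand for weaker inhibition and lower numbers for stronger inhibition:
compound 1 `Cc1ccc(-c2cc(/N=C3/NC(=O)CS3)cs2)cc1` with > 50000 nM.
compound 2 `O=C1CS/C(=N\c2csc(-c3ccccc3)c2)N1` with > 50000 nM.
compound 3 `COc1cccc(N2C(=O)CS/C2=N\c2csc(-c3ccccc3)c2)c1` with "not determined" (no result reported).

The value of compound 1 is a limit of this assay, not a number. The value of compound 2 is likewise a limit of this assay. Compound 3 has no result reported in this assay, so it stands on no number of its own; the two other values around it are both limits, as shown by the limit of > 50000 nM in this assay, at which 2 of the 3 values shown sit. For the measured compounds named here, the only single-point step among the measured compounds, a step that the two limits leave unreadable from compound 1 to compound 2, cannot be read in size, since both ends sit at that limit.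

Compound 4 `COc1cccc(N2C(=O)CS/C2=N\c2csc(-c3ccc(C)cc3)c2)c1` differs from compound 3 by methyl in place of hydrogen on an aromatic carbon. The measured step that bears on this change is a step that the two limits leave unreadable from compound 1 to compound 2, the same change in the opposite direction, and it is unreadable. Going by the values given here, with compound 3 unmeasured and compound 1 and compound 2 both at the limit, no step in this assay can be expected with any direction. Compound 4 is therefore estimated at 50000 nM, within a range from 20000 nM to 100000 nM, with a high chance that only a limit is reported.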

Compound 4, half-maximal inhibitory concentration: 41000 nM
The estimate for compound 4 lay 1.2-fold (0.09 log units) above the measured number, and the stated range covers the measured number.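

In this assay, compound 4 is the first of the compounds shown to give a number rather than a limit: the limit of > 50000 nM in this assay, at which 2 of the 4 values shown sit. With 3-methoxyphenyl in place of hydrogen on the amide-type nitrogen in a ring, the result is an at least 1.2-fold lower number from compound 1 to compound 4 (0.08 log units; that floor lies within the scatter), so this step gives only a floor, set by the limit of compound 1, and does not establish a change at this position. Going by these compounds, the other steps cannot be read, and with no result reported for compound 3, the effect of phenyl to 4-methylphenyl remains unknown here.

The compounds shown leave open whether an amine or a carboxylic acid on the ring of the 3-methoxyphenyl group, or a longer chain in its place on that nitrogen, would shift the number beyond the scatter. They also leave open how a chlorine in place of the methyl of compound 4 would read.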